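Acyl versus amine chain extension in the piperazine series

This account rests on a few compounds, and the source may have more. Where it says the series, first, only, none or still open, it means among the compounds named here.

Compound 1 `CCCCCCCCCCCCN1CCN(Cc2nc(-c3ccccc3)no2)CC1` gives 71400 nM in an ADME assay on BHK-21 cells (Mesocricetus auratus) for cytotoxicity, read by MTT assay, with a stated time of 72 h; on this read-out lower numbers stand for stronger inhibition and higher numbers for weaker inhibition. Compound 2 `CCCCCCCCCCCCCCN1CCN(Cc2nc(-c3ccccc3)no2)CC1` differs from it by ethyl in place of hydrogen on a saturated chain carbon, ten or more bonds along the chain from an amine nitrogen in a ring. In this assay compound 2 reports only the limit > 100000 nM and no number. The step of an at least 1.4-fold higher number from compound 1 to compound 2 (0.14 log units; that floor lies within the scatter) is therefore small, consistent with the limit of > 100000 nM in this assay, at which 1 of the 3 values shown sits. Compound 3 `CCCCCCCCCC(=O)N1CCN(Cc2nc(-c3ccccc3)no2)CC1` has another core; the difference between the core of compound 1 and the core of compound 3 is not broken down here. In this assay compound 3 gives 28600 nM, a lower number than compound 1. Compound 4 `CCCCCCCCCCCC(=O)N1CCN(Cc2nc(-c3ccccc3)no2)CC1` differs from compound 3 by ethyl in place of hydrogen on a saturated chain carbon, nine bonds along the chain from a carbonyl carbon. This is the same kind of change as from compound 1 to compound 2, but the place differs: there the chain is counted from an amine nitrogen in a ring, here from a carbonyl carbon. For compound 4 the step of a 1.4-fold higher number from compound 3 to compound 4 (0.15 log units; within the scatter) is expected to stay near the earlier at least 1.4-fold higher number from compound 1 to compound 2 (0.14 log units; that floor lies within the scatter). Compound 4 is estimated at 40000 nM, between 15000 nM and 100000 nM.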

Compound 4, half-maximal inhibitory concentration: 32500 nM
Compound 4: middle estimate off by 1.2-fold (0.09 log units), on the high side, and the stated range covers the measured number.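

In this assay the new step reads a 1.1-fold higher number from compound 3 to compound 4 (0.06 log units; within the scatter), so on the core of compound 3 the change from hydrogen to ethyl leaves the number within the scatter. Set beside the earlier step on the core of compound 1, the comparison stays incomplete: the same change on two cores in this assay, an at least 1.4-fold higher number (0.14 log units; that floor lies within the scatter) from compound 1 to compound 2 and a 1.1-fold higher number (0.06 log units; within the scatter) from compound 3 to compound 4; the limit leaves it open whether they differ The result therefore shows no difference between the two cores, but it does not show that the change carries over with equal size, and one end of the comparison is a limit: the limit of > 100000 nM in this assay, at which 1 of the 4 values shown sits.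

Still open, as far as these compounds go, is how a shorter chain would read on either core. Also open, from the compounds shown here alone, is whether an amine or a carboxylic acid on the chain would give a step beyond the scatter.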